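Fluoro for methyl on the aryl group of compound 2

The source may report more compounds than this note shows. Statements on the series, on what has been measured and on what is new or still open speak of the compounds shown alone.

Measured compounds:
compound 1 `COc1ccc(Cc2cc(-c3ccc(OC)cc3)nn(CC(=O)Nc3ccc(Br)cc3)c2=O)cc1` — > 50000 nM
compound 2 `COc1ccc(Cc2cc(-c3ccc(C)cc3)nn(CC(=O)Nc3ccc(Br)cc3)c2=O)cc1` — > 50000 nM

In an assay on HL-60 cells for agonist activity at N-formyl peptide receptor 3 (Homo sapiens), read by calcium flux (on this read-out lower numbers stand for an effect already at smaller amounts and higher numbers for an effect only at larger amounts of compound), compound 1 reaches only a limit of the assay, > 50000 nM. In this assay compound 2 likewise gives a limit, > 50000 nM. Going by the values given here, the one measured step, a step that the two limits leave unreadable from compound 1 to compound 2, therefore cannot be read: both values sit at the limit of > 50000 nM in this assay, at which 2 of the 2 values shown sit, and whether the change of methoxy to methyl moved the number at all is hidden behind that limit. So compound 2 stands at the edge of what this assay reports, with no number of its own.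

Compound 3 `COc1ccc(Cc2cc(-c3ccc(F)cc3)nn(CC(=O)Nc3ccc(Br)cc3)c2=O)cc1` differs from compound 2 by fluoro in place of methyl on an aromatic carbon. Among the compounds with values here, the only measured step bears on the same aromatic carbon, but its size is unreadable, so no measured step gives a direction or size for the change from methyl to fluoro. With both neighbours of compound 3 at the limit, the expectation is that compound 3 also falls at or beyond the limit in this assay, an expected step that the limit leaves unreadable from compound 2 to compound 3. Compound 3 is estimated at 60000 nM, with a range from 20000 nM to 200000 nM.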

Compound 3, half-maximal effective concentration: > 50000 nM
Compound 3 was reported as a limit; the forecaster's own chance of this, stated with the estimate: 85%; the middle value does not contradict the limit.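

Going by these compounds alone, no step among compound 1, compound 2 and compound 3 can be read, since compound 3 joins the other two at a limit and not a number: the limit of > 50000 nM in this assay, at which 3 of the 3 values shown sit. The compounds shown leave open whether methoxy, methyl or fluoro on this aryl group changes the result in this assay at all, and at what concentration any of them would show an effect.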